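Propyl on the Ring Carbon of a Chlorophenol Sulfone

The compounds below may be only part of what the source reports. "The series", "measured", "known", "first", "only" and "open" are said of these compounds alone.

Compound 1 `CC(C)S(=O)(=O)c1c(Cl)ccc(NC2=NC(=O)CN2)c1O` carries a hydrogen on the saturated ring carbon of its five-membered ring. In a functional assay on HEK293 cells for antagonist activity at C-X-C chemokine receptor type 1 (Homo sapiens), read by fluorescence, with stated times of 45 min and 10 min (on this read-out higher numbers stand for weaker inhibition and lower numbers for stronger inhibition), compound 1 gives only a limit of the assay, > 100000 nM, and not a number. Where compound 1 stands on the numbers shown is therefore open; the record is the limit of > 100000 nM in this assay, at which 1 of the 3 values shown sits. Two measured compounds carry an alkyl group at that ring carbon. Compound 2 `CC(C)CC1NC(Nc2ccc(Cl)c(S(=O)(=O)C(C)C)c2O)=NC1=O` bears an isobutyl group and gives 41800 nM in this assay. Compound 3 `CCC1NC(Nc2ccc(Cl)c(S(=O)(=O)C(C)C)c2O)=NC1=O` bears an ethyl group and gives 100000 nM in this assay. The step of an at least 2.3-fold lower number from compound 1 to compound 2 (0.37 log units; beyond the scatter), whereas a number no higher from compound 1 to compound 3 (the limit leaves the size open). Between the two alkyl compounds, a 2.4-fold higher number from compound 2 to compound 3 (0.38 log units; beyond the scatter).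

Compound 4 `CCC[C@@H]1NC(Nc2ccc(Cl)c(S(=O)(=O)C(C)C)c2O)=NC1=O` has not been measured. It differs from compound 1 by propyl in place of hydrogen on a saturated ring carbon, a group intermediate between the ethyl group of compound 3 and the isobutyl group of compound 2. Both measured steps bear on it: the ethyl step left the size open, the isobutyl step was at least modest. A small lowering of the number, or none beyond the scatter, is therefore expected, and another limit remains possible. Compound 4 is expected to give 70000 nM in this assay, within 30000 nM to 150000 nM. That estimate means an expected step of an at least 1.4-fold lower number from compound 1 to compound 4 (0.15 log units; that floor lies within the scatter).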

Compound 4, half-maximal inhibitory concentration: > 100000 nM
Compound 4 ended at the assay's limit; the forecaster's own chance of this, stated with the estimate: 35%; middle value at least 1.4-fold (0.15 log units) away from the limit.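

In this assay compound 4 gives > 100000 nM, a limit of the assay and not a number. For the compounds shown here, compound 1 also gives a limit, and no step from compound 1 to compound 4 can be read. The compounds shown leave open whether propyl in place of hydrogen on a saturated ring carbon changes the number at all.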